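The source may report more compounds than this note shows. Statements on the series, on what has been measured and on what is new or still open speak of the compounds shown alone.

Measured in a functional assay on A549 cells (Homo sapiens) for cytotoxicity, read by MTT assay, with a stated time of 72 h; a lower number here means a stronger inhibitor, a higher number a weaker inhibitor:
- compound 1 `O=C(/C=C/c1ccc([N+](=O)[O-])cc1)Nc1cc2c(Nc3ccc(F)c(Cl)c3)ncnc2cc1O[C@H]1CCOC1`: 12000 nM
- compound 2 `O=C(/C=C/c1cccc(Cl)c1Cl)Nc1cc2c(Nc3ccc(F)c(Cl)c3)ncnc2cc1O[C@H]1CCOC1`: 23200 nM
- compound 3 `COc1ccc(/C=C/C(=O)Nc2cc3c(Nc4ccc(F)c(Cl)c4)ncnc3cc2OC)cc1`: "not active" (no number reported)

Only two of these compounds carry a number in this assay, and they lie within the scatter of each other. Within the data shown here, compound 2 stands at 23200 nM, and the one step that reaches it is a 1.9-fold higher number from compound 1 to compound 2 (0.29 log units; within the scatter). Among the measured compounds shown here, compound 3 has no number, so it offers no step to work from.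

The next compound is compound 4 `O=C(/C=C/c1ccccc1[N+](=O)[O-])Nc1cc2c(Nc3ccc(F)c(Cl)c3)ncnc2cc1O[C@H]1CCOC1`, which keeps the rest of compound 2 and changes one group: 2-nitrophenyl in place of 2,3-dichlorophenyl on a double-bonded chain carbon bound to a double-bonded chain carbon. In words, 2-nitrophenyl comes in place of 2,3-dichlorophenyl on a double-bonded chain carbon bound to a double-bonded chain carbon.

The measured step bearing on this change is the one at the same place, where 2,3-dichlorophenyl replaced 4-nitrophenyl: a 1.9-fold higher number from compound 1 to compound 2 (0.29 log units; within the scatter). For the measured compounds named here, that step stayed within the scatter, so the one exchange measured at this place gives no sign of a large effect. Going by the values given here, it is a single step, however, and no compound with 2-nitrophenyl has been measured. As far as these compounds go, no step beyond the scatter is therefore expected in this assay, and the direction stays open. The expected change is a 1.5-fold lower number from compound 2 to compound 4 (0.16 log units; within the scatter).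

For compound 4 the estimate is 16000 nM, with an expected range from 6000 nM to 40000 nM.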

Compound 4, half-maximal inhibitory concentration: 8820 nM
Estimate against measurement, compound 4: 1.8-fold (0.26 log units) above; the range from low to high includes it.
By their numbers in this assay, from the lowest: compounds 4, 1 and 2 (each within the scatter of the next, the first and the last beyond it).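

In this assay, the exchange at this place, on a double-bonded chain carbon bound to a double-bonded chain carbon, now gives a step beyond the scatter: a 2.6-fold lower number from compound 2 to compound 4 (0.42 log units; beyond the scatter). The step is modest, but it shows that the aryl group here can shift the number measurably, which the earlier step between compound 1 and compound 2 could not show. The step between the two nitrophenyl groups, a 1.4-fold lower number from compound 1 to compound 4 (0.13 log units; within the scatter), stays within the scatter, so this assay does not separate 2-nitrophenyl from 4-nitrophenyl, and compound 1 does not fall clearly on either side of the gap between compound 2 and compound 4; no measurement offered here accounts for that gap.

The compounds shown leave open whether the step follows the loss of the chlorine atoms or the arrival of the nitro group, as no compound here carries a plain phenyl at this place. They also leave open how an aminophenyl or a phenyl bearing a carboxylic acid would read in this assay, and whether any group at this place can bring the number far below those seen so far.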